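Shifting the amino group in the nitrophenyl compound

The source may report more compounds than this note shows. Statements on the series, on what has been measured and on what is new or still open speak of the compounds shown alone.

- Compound 1 `COc1cc(C(=O)c2cn(-c3cccc(N)c3)cc2-c2ccccc2F)cc(OC)c1OC` in a functional assay on MCF7 cells (Homo sapiens) for cytotoxicity, read by MTT assay, with a stated time of 96 h (on this read-out lower numbers stand for stronger inhibition and higher numbers for weaker inhibition), gives 17 nM
- Compound 2 `COc1cc(C(=O)c2cn(-c3cccc(N)c3)cc2-c2cccc([N+](=O)[O-])c2)cc(OC)c1OC` in this assay gives 510 nM

Of the two numbers in this assay the higher belongs to compound 2 at 510 nM and the nearest value is that of compound 1. Among the compounds with values here, the single measured step is large and beyond the scatter (a 30-fold higher number from compound 1 to compound 2 (1.48 log units; beyond the scatter)) and it puts 3-nitrophenyl in place of 2-fluorophenyl on an aromatic carbon.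

Compound 3 `COc1cc(C(=O)c2cn(-c3ccc(N)cc3)cc2-c2cccc([N+](=O)[O-])c2)cc(OC)c1OC` differs from compound 2 at another place (4-aminophenyl in place of 3-aminophenyl on an aromatic nitrogen) with 4-aminophenyl in place of 3-aminophenyl on an aromatic nitrogen. Within the data shown here, no measured step covers this exchange, and the one available step gives neither a size nor a direction for it. The estimate therefore stays anchored on compound 2 at 510 nM and the range is kept wide. The estimated step is a 1.3-fold lower number from compound 2 to compound 3 (0.11 log units; within the scatter) and no firm shift beyond the scatter is expected in this assay for either direction. Compound 3 is estimated at 400 nM (expected range 100 nM to 1800 nM).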

Compound 3, half-maximal inhibitory concentration: 260 nM
Compound 3: middle estimate off by 1.5-fold (0.19 log units), on the high side; low and high end bracket the measured number.
By their numbers in this assay, from the lowest: compound 1; then compounds 3 and 2 (each within the scatter of the next).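

Within the data shown here, the exchange of 3-aminophenyl for 4-aminophenyl on the aromatic nitrogen gives the first reading on that substituent in this assay: a 2.0-fold lower number from compound 2 to compound 3 (0.29 log units; within the scatter) is the size of the step, so the two amino placements cannot be told apart on the 3-nitrophenyl background. Among these compounds, the only other step, made on an aromatic carbon two ring bonds away, is far larger at a 30-fold higher number from compound 1 to compound 2 (1.48 log units; beyond the scatter) and lies beyond the scatter, so with these three compounds the clear difference in this assay sits with the carbon substituent and not with the amino placement. Nothing at hand gives a reason for either step.

Open, on these data alone, is whether the amino placement counts for as little on the 2-fluorophenyl background, where compound 1 gives 17 nM in this assay and a larger gap could show up more readily than on the 3-nitrophenyl background. Also open, as far as these compounds go, is how a hydroxyl, a methoxy group or an acetamide would read in place of the amino group on the phenyl carried by the ring nitrogen.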